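Swapping a carbamate for a difluoroacetamide on the side chain

This account rests on a few compounds, and the source may have more. Where it says the series, first, only, none or still open, it means among the compounds named here.

Compound 3 `COC(=O)NC[C@H]1CN(c2ccc(-n3cc(-c4ccccn4)cn3)c(F)c2)C(=O)O1` gives 71 ug/mL in an ADME assay on L02 cells (Homo sapiens) for cytotoxicity, read by MTT assay, with a stated time of 48 h; on this read-out higher numbers stand for weaker inhibition and lower numbers for stronger inhibition. It is one of only two plain numbers shown; the other, from compound 1 `CN1CCN(C[C@H]2CN(c3ccc(-n4cc(-c5ccccn5)cn4)c(F)c3)C(=O)O2)CC1` at 70 ug/mL, lies within the scatter of it. Compound 2 `CC(=O)OC[C@H]1CN(c2ccc(-n3cc(-c4ccccn4)cn3)c(F)c2)C(=O)O1` gives only > 400 ug/mL, which is a limit of the assay rather than a number (the limit of > 400 ug/mL in this assay, at which 1 of the 3 values shown sits). Compound 4 `O=C(NC[C@H]1CN(c2ccc(-n3cc(-c4ccccn4)cn3)c(F)c2)C(=O)O1)C(F)F` differs from compound 3 in one place: difluoromethyl in place of methoxy on a carbonyl carbon. Within the data shown here, no measured step changes this carbonyl substituent; the known steps replace the whole chain group, a 1.0-fold higher number from compound 1 to compound 3 (0.01 log units; within the scatter) and an at least 5.6-fold lower number from compound 2 to compound 3 (0.75 log units; beyond the scatter). With no direct guide, the number for compound 4 is expected to stay close to that of compound 3, a 1.0-fold lower number from compound 3 to compound 4 (0.01 log units; within the scatter). Compound 4 is therefore estimated at 70 ug/mL, between 30 ug/mL and 200 ug/mL.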

Compound 4, half-maximal inhibitory concentration: > 400 ug/mL
Compound 4 gave a limit, no number; the forecaster's own chance of this, stated with the estimate: 15%; at least 5.7-fold (0.75 log units) between middle value and limit.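

In this assay, changing only the group on the carbonyl carbon, difluoromethyl for methoxy, gives an at least 5.6-fold higher number from compound 3 to compound 4 (0.75 log units; beyond the scatter), so this one substituent can weaken the inhibition beyond the scatter. The change from the chain of compound 1 gives an at least 5.7-fold higher number from compound 1 to compound 4 (0.75 log units; beyond the scatter), whereas the carbamate chain of compound 3 had shown no such separation from compound 1. The step from compound 2 to compound 4 cannot be read, because both are limits: the limit of > 400 ug/mL in this assay, at which 2 of the 4 values shown sit.

From the compounds shown here alone, how far compound 4 lies past its limit stays open. So does whether the fluorine atoms matter, which a plain methyl or a trifluoromethyl on this carbonyl carbon could help to show.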